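Swapping a furan ring for a chlorophenyl on a pyridine core

This account rests on a few compounds, and the source may have more. Where it says the series, first, only, none or still open, it means among the compounds named here.

Of the compounds shown here, three have been tested in a functional assay on MCF7 cells (Homo sapiens) for cytotoxicity, read by ELISA, with a stated time of 4 days; on this read-out lower numbers stand for stronger inhibition and higher numbers for weaker inhibition. Compound 1 `Clc1ccc(-c2cc(-c3ccoc3)cc(-c3ccco3)n2)s1` gives 4740 nM, compound 2 `Clc1cccc(-c2cc(-c3ccoc3)cc(-c3ccc(Cl)s3)n2)c1` gives 2920 nM, and compound 3 `Cc1ccsc1-c1cc(-c2ccc(Cl)o2)cc(-c2ccco2)n1` gives 5570 nM. Compound 1 and compound 2 differ in one place, (3-chlorophenyl in place of furan-2-yl on an aromatic carbon), and the step is a 1.6-fold lower number from compound 1 to compound 2 (0.21 log units; within the scatter). Compound 4 `Cc1ccsc1-c1cc(-c2ccc(Cl)o2)cc(-c2cccc(Cl)c2)n1` has not been measured; it differs from compound 3 by 3-chlorophenyl in place of furan-2-yl on an aromatic carbon, the same kind of change, made on a core that carries a 3-methylthiophen-2-yl group and a 5-chlorofuran-2-yl group where the core of compound 1 carries a 5-chlorothiophen-2-yl group and a furan-3-yl group. How the two cores differ is not broken down here. Because the earlier step was a 1.6-fold lower number from compound 1 to compound 2 (0.21 log units; within the scatter), a step of similar size is expected from compound 3 to compound 4, about a 1.6-fold lower number from compound 3 to compound 4 (0.20 log units; within the scatter). Compound 4 is therefore estimated at 3500 nM in this assay, between 1500 nM and 9000 nM.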

Compound 4, half-maximal inhibitory concentration: 18800 nM
Compound 4: middle estimate off by 5.4-fold (0.73 log units), on the low side, and the stated range ends below it.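

In this assay, the replacement of furan-2-yl by 3-chlorophenyl gives a 3.4-fold higher number from compound 3 to compound 4 (0.53 log units; beyond the scatter), so the earlier step did not carry over to this core. The two results differ in direction as well as size: the same change on two cores in this assay, a 1.6-fold lower number (0.21 log units; within the scatter) from compound 1 to compound 2 and a 3.4-fold higher number (0.53 log units; beyond the scatter) from compound 3 to compound 4, 5.5-fold (0.74 log units) apart, beyond the scatter of two such steps. Within the data shown here, this shows that, in this series, the effect of the change on one core cannot be taken as a guide to its effect on the other, but it does not show which of the differences between the two cores is responsible, and only two pairs are available.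

The compounds shown leave open whether the 3-methylthiophen-2-yl group or the 5-chlorofuran-2-yl group governs the response to this change, for the two appear only together. Also open, on these data alone, is how a non-aromatic group next to the ring nitrogen, such as an amine or a carboxylic acid, would behave on either core.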